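Exchanging (pent-4-en-1-yl)oxy for phenylsulfonyl on a shared core

The source may report more compounds than this note shows. Statements on the series, on what has been measured and on what is new or still open speak of the compounds shown alone.

Compound 1 `C=CCCCCOc1ccccc1-c1cnc(OCCCC=C)n1C`: 7000 nM
Compound 2 `C=CCCCCOc1ncc(-c2ccc(Cl)cc2OC)n1C`: 37000 nM

Both compounds were tested in a functional assay on MCF7 cells (Homo sapiens) for inhibition, read by colorimetric assay and MTT assay, with a stated time of 72 h; on this read-out lower numbers stand for stronger inhibition and higher numbers for weaker inhibition. Compound 1, at 7000 nM, has the lower number of the two and so the stronger inhibition. Compound 2, at 37000 nM, lies above it by a gap beyond the usual scatter. Among the measured compounds shown here, with only two measured compounds, this places compound 1 at the better end of a very short series.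

Compound 3 `C=CCCCCOc1ccccc1-c1cnc(S(=O)(=O)c2ccccc2)n1C` keeps the core of compound 1 but carries phenylsulfonyl in place of (pent-4-en-1-yl)oxy on an aromatic carbon. This carbon lies between two ring nitrogen atoms. The entering group brings one six-membered aromatic ring of carbon only, whereas the leaving group has no ring.

For the measured compounds named here, no two measured compounds differ in one place only, so the data offer no direct guide to this exchange. No step beyond the scatter is therefore expected in this assay, and the estimated change is a 1.4-fold higher number from compound 1 to compound 3 (0.15 log units; within the scatter). For compound 3 the estimated value is 10000 nM, with an expected range from 3000 nM to 40000 nM.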

Compound 3, half-maximal inhibitory concentration: 25000 nM
Beside the measured number, compound 3's estimate is 2.5-fold (0.40 log units) below it, and the stated range covers the measured number.
By their numbers in this assay, from the lowest: compound 1; then compounds 3 and 2 (each within the scatter of the next).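

In this assay, among the compounds shown here, this is the first measured exchange at the aromatic carbon between two ring nitrogen atoms: phenylsulfonyl in place of (pent-4-en-1-yl)oxy gives a 3.6-fold higher number from compound 1 to compound 3 (0.55 log units; beyond the scatter), a modest step but one beyond the scatter. It shows that inhibition in this series is not indifferent to what this carbon carries, as the open chain with its double bond and no ring goes with the lower number, while the entering group, with more heavy atoms and one six-membered aromatic ring of carbon only, goes with a higher one, although compound 3 still gives a measurable 25000 nM. No measurement at hand gives a reason for this step.

The compounds shown carry only these two groups at this carbon in an otherwise unchanged core, so they do not separate the part played by the entering group's ring from that of its sulfonyl link. Going by these compounds, a phenoxy group or an amine at the same carbon would bear on that question, and whether a shorter or longer chain on the oxygen would move the number remains open as well.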